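The source may report more compounds than this note shows. Statements on the series, on what has been measured and on what is new or still open speak of the compounds shown alone.

Measured in a functional assay on PC-3 cells (Homo sapiens) for inhibition, read by MTT assay, with a stated time of 48 h; on this read-out lower numbers stand for stronger inhibition and higher numbers for weaker inhibition:
- Compound 1 `COc1cc(-c2nnc(SCc3ccccc3)n2-c2ccc(N(C)C)cc2)cc(OC)c1OC`: 55800 nM
- Compound 2 `COc1cc(-c2nnc(SCc3ccc(F)cc3)n2-c2ccc(N(C)C)cc2)cc(OC)c1OC`: 46500 nM
- Compound 3 `COc1ccc(C(=O)CSc2nnc(-c3cc(OC)c(OC)c(OC)c3)n2-c2ccc(N(C)C)cc2)cc1`: 22000 nM

Compound 3 has the lowest number of the three, and its steps from both others lie beyond the scatter, though both are modest: a 2.5-fold lower number from compound 1 to compound 3 (0.40 log units; beyond the scatter) and a 2.1-fold lower number from compound 2 to compound 3 (0.33 log units; beyond the scatter). Among the measured compounds shown here, the one ring change measured, a 1.2-fold lower number from compound 1 to compound 2 (0.08 log units; within the scatter), stays within the scatter.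

Compound 4 `COc1cc(-c2nnc(SCC(=O)Nc3ccc(Cl)cc3)n2-c2ccc(N(C)C)cc2)cc(OC)c1OC` has not yet been measured. It differs from compound 3 on the side chain: (4-chlorophenyl)amino in place of 4-methoxyphenyl on a carbonyl carbon. The carbonyl stays in place, and an aromatic ring of carbon only is still present in the group that enters. For the measured compounds named here, no measured step makes this exchange directly, so the data give no direction for it. The modest size of the steps to compound 3 argues against expecting a large shift, and no step beyond the scatter is expected in this assay.

The expected step is a 1.1-fold higher number from compound 3 to compound 4 (0.04 log units; within the scatter). For compound 4 the estimated value is 24000 nM, with an expected range from 9000 nM to 55000 nM.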

Compound 4, half-maximal inhibitory concentration: > 60000 nM
Compound 4 ended at the assay's limit; the forecaster's own chance of this, stated with the estimate: 5%; middle value at least 2.5-fold (0.39 log units) from the limit.
By their numbers in this assay, from the lowest: compound 3; then compounds 2 and 1 (each within the scatter of the next). At a limit, above all of these: compound 4.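

In this assay, (4-chlorophenyl)amino in place of 4-methoxyphenyl on a carbonyl carbon gives an at least 2.7-fold higher number from compound 3 to compound 4 (0.43 log units; beyond the scatter). The carbonyl stays in place in compound 4, so its presence alone does not keep the number as low as in compound 3; what enters with the exchange is a group with a hydrogen-bond donor and a chlorine in place of the methoxy oxygen. The two other steps to compound 4 give only floors that lie within the scatter: an at least 1.2-fold higher number from compound 2 to compound 4 (0.11 log units; that floor lies within the scatter) and an at least 1.0-fold higher number from compound 1 to compound 4 (0.03 log units; that floor lies within the scatter). The value of compound 4 is a limit, not a number: the limit of > 60000 nM in this assay, at which 1 of the 4 values shown sits.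

The exchange alters the amino link and the ring substituent together, and the compounds shown do not separate the two. A 4-chlorophenyl or a (4-methoxyphenyl)amino group on that carbonyl carbon would tell them apart.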